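Notes on compound 2 and its furan-3-yl analogue

A few compounds are considered here, and "the series" means these few. Any claim that something is new, unique, unknown or untested is made for them only; others in the source may bear on it.

Compounds measured in a functional assay on PC-3 cells (Homo sapiens) for antiproliferative activity, read by CCK-8 assay, with a stated time of 6 days; a higher number here means a weaker inhibitor, a lower number a stronger inhibitor:
compound 1 `N#Cc1ccc(N2CCc3cc(-c4cncnc4)ccc32)cc1C(F)(F)F` — compound 1 gives "not determined" (no result reported).
compound 2 `CCN(c1ccc(C#N)c(Cl)c1)c1cc(-c2cncnc2)ccc1C` — compound 2 gives > 30000 nM, a limit of the assay.
compound 3 `CCN(c1cccc(-c2cncnc2)c1)c1ccc(C#N)c(Cl)c1` — compound 3 gives > 30000 nM, a limit of the assay.

Compound 2 stands only at a limit in this assay; compound 3 stands at the same limit and compound 1 has no result, so no single number places compound 2 within the set. (the limit of > 30000 nM in this assay, at which 2 of the 3 values shown sit). For the measured compounds named here, the one step available within the measured set, a step that the two limits leave unreadable from compound 2 to compound 3, cannot be read, both ends being limits.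

Compound 4 `CCN(c1ccc(C#N)c(Cl)c1)c1cc(-c2ccoc2)ccc1C` differs from compound 2 as follows: furan-3-yl in place of pyrimidin-5-yl on an aromatic carbon. Going by the values given here, no measured step touches this group, so nothing read from the set bears on the change, and no direction can be drawn from it. Starting from a limit, the step expected in this assay is a step that the limit leaves unreadable from compound 2 to compound 4, itself unreadable. Compound 4 is expected to give 40000 nM, within 10000 nM to 150000 nM, with a limit rather than a number the most likely report.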

Compound 4, half-maximal inhibitory concentration: > 30000 nM
Compound 4: only a limit was reported; the forecaster's own chance of this, stated with the estimate: 80%; the middle value is on the limit's open side.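

No new step can be read from compound 2 to compound 4, since each stands only at a limit of the assay: the limit of > 30000 nM in this assay, at which 3 of the 4 values shown sit.

The compounds shown leave open whether furan-3-yl in place of pyrimidin-5-yl changes antiproliferative activity at all, and what single number either compound would give.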